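Swapping 3-hydroxyphenyl for phenoxy: what to expect

The source may report more compounds than this note shows. Statements on the series, on what has been measured and on what is new or still open speak of the compounds shown alone.

Compound 1 `COc1ccc(Cn2nnc(O)c2C(=O)Nc2cccc(-c3ccccc3)c2)cc1` gives 52100 nM
Compound 2 `COc1ccc(Cn2nnc(O)c2C(=O)Nc2cccc(-c3cccc(O)c3)c2)cc1` gives 75700 nM

For the measured compounds named here, in a functional assay on CWR22R cells (Homo sapiens) for inhibition, read by sulforhodamine B assay, with a stated time of 72 h (on this read-out higher numbers stand for weaker inhibition and lower numbers for stronger inhibition), compound 2 sits at 75700 nM and cannot be told apart from compound 1, the only other measured compound. Compound 3 `COc1ccc(Cn2nnc(O)c2C(=O)Nc2cccc(Oc3ccccc3)c2)cc1` differs from compound 2 in one place: phenoxy in place of 3-hydroxyphenyl on an aromatic carbon. Going by the values given here, the only measured step, a 1.5-fold higher number from compound 1 to compound 2 (0.16 log units; within the scatter), put hydroxy in place of hydrogen. Among the compounds with values here, it is a weak guide, as no measured compound carries phenoxy. Nothing therefore points to a change beyond the scatter, and a 1.4-fold lower number from compound 2 to compound 3 (0.14 log units; within the scatter) is the expected step. For compound 3 the estimate is 55000 nM, with an expected range from 22000 nM to 120000 nM on repeat measurement.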

Compound 3, half-maximal inhibitory concentration: 65000 nM
Beside the measured number, compound 3's estimate is 1.2-fold (0.07 log units) below it, within the range that was stated.
By their numbers in this assay, from the lowest: compounds 1, 3 and 2 (each within the scatter of the next).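

Phenoxy in place of 3-hydroxyphenyl gives a 1.2-fold lower number from compound 2 to compound 3 (0.07 log units; within the scatter) even though the hydrogen-bond donor is lost, and phenoxy in place of phenyl gives a 1.2-fold higher number from compound 1 to compound 3 (0.10 log units; within the scatter) with an oxygen link added. At this position, then, these three aromatic groups cannot be told apart, whether joined directly or through oxygen. Nothing available explains why the numbers stay so close.

Going by these compounds, whether an amine, a carboxylic acid or a longer chain at this place would shift the number beyond the scatter remains open.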